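A Larger Basic Amide Substituent on a Shared Fluorinated Core

A few compounds are considered here, and "the series" means these few. Any claim that something is new, unique, unknown or untested is made for them only; others in the source may bear on it.

Among the compounds with values here, compound 1 `CC1=C(CC(=O)N(C)CCN(C)C)c2cc(F)ccc2/C1=C\c1nc2ccccc2s1` is one of three compounds measured in a functional assay on HT-29 cells (Homo sapiens) for inhibition, read by CellTiter-Glo, with a stated time of 72 h; on this read-out lower numbers stand for higher toxicity in this test and higher numbers for lower toxicity in this test. In this assay compound 1 gives 2020 nM, the lowest number of the three. Compound 2 `CC1=C(CC(=O)NCCN(C)C)c2cc(F)ccc2/C1=C\c1ccncc1` gives 6890 nM, and compound 3 `CC1=C(CC(=O)NCCN(C)C)c2cc(F)ccc2/C1=C\c1ccc(S(C)(=O)=O)cc1` gives 12700 nM; compound 1 stands beyond the scatter from both of them. Within the data shown here, the only step between measured compounds that differ in one place is a 1.8-fold higher number from compound 2 to compound 3 (0.27 log units; within the scatter), a change of the group on the double-bonded chain carbon, not of the amide.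

Compound 4 `CC1=C(CC(=O)N2CCN(CCCN(C)C)CC2)c2cc(F)ccc2/C1=C\c1nc2ccccc2s1` differs from compound 1 on the carbonyl carbon: 4-(3-(dimethylamino)propyl)piperazin-1-yl in place of (2-(dimethylamino)ethyl)(methyl)amino on a carbonyl carbon. Among the measured compounds shown here, no measured pair alters the group on the carbonyl carbon, so the step from compound 2 to compound 3 does not bear on this change directly; it shows only that one change on the other side of the core stayed within the scatter. With nothing in the data pointing in either direction, for compound 4 the expected step in this assay is a 1.2-fold higher number from compound 1 to compound 4 (0.09 log units; within the scatter), small and without a clear direction, and the range is kept wide for want of a precedent. Compound 4 is therefore estimated at 2500 nM, between 800 nM and 8000 nM.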

Compound 4, half-maximal cytotoxic concentration: 1620 nM
Estimate against measurement, compound 4: 1.5-fold (0.19 log units) above; the range from low to high includes it.
By their numbers in this assay, from the lowest: compounds 4 and 1 (each within the scatter of the next); then compounds 2 and 3 (each within the scatter of the next).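

On the carbonyl carbon, the first change shown at this position gives a 1.2-fold lower number from compound 1 to compound 4 (0.10 log units; within the scatter) in this assay, so the read-out stays within the usual scatter. The entering 4-(3-(dimethylamino)propyl)piperazin-1-yl has 12 heavy atoms and one six-membered non-aromatic ring with 2 hetero atoms, whereas the leaving (2-(dimethylamino)ethyl)(methyl)amino has 7 heavy atoms and no ring, so on this core and in this test the position accepts a clearly larger group with a ring and shows no separable effect on the number. Nothing measured here offers an explanation for this result, and no supporting data on the compounds accompany it.

The compounds shown leave open how a morpholin-4-yl group, a carboxylic acid or a longer chain on the carbonyl carbon would read in this test, since only two groups can be compared at this position directly. They also leave open whether the same exchange would give a comparable step with pyridin-4-yl or 4-(methylsulfonyl)phenyl on the double-bonded chain carbon in place of the group that compound 1 and compound 4 share.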